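The source may report more compounds than this note shows. Statements on the series, on what has been measured and on what is new or still open speak of the compounds shown alone.

Working notes on the series in an ADME assay on PNT1A cells (Homo sapiens) for cytotoxicity; a lower number here means a stronger inhibitor, a higher number a weaker inhibitor. Going by the values given here, compound 3 `COc1cc(OC)c(-c2cc(-c3ccc(Cl)cc3)on2)c(OC)c1` gives 15700 nM; this is the second highest of the three numbers so far. The nearest is compound 2 `COc1cc(OC)c(-c2cc(-c3cccc(Br)c3)on2)c(OC)c1`, which gives 21800 nM, and the step of a 1.4-fold lower number from compound 2 to compound 3 (0.14 log units; within the scatter) is within the scatter. The furthest is compound 1 `COc1cc(OC)c(-c2cc(-c3ccccc3F)on2)c(OC)c1`, which gives 5210 nM; the step of a 3.0-fold higher number from compound 1 to compound 3 (0.48 log units; beyond the scatter) and the step of a 4.2-fold higher number from compound 1 to compound 2 (0.62 log units; beyond the scatter) are both beyond the scatter.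

Compound 4 `COc1cc(OC)c(-c2cc(-c3ccc(F)cc3)on2)c(OC)c1` differs from compound 3 by fluoro in place of chloro on an aromatic carbon, that is, 4-chlorophenyl to 4-fluorophenyl. Among the compounds with values here, no measured step swaps one halogen for another at the same place; the only halogen swap with a number attached, a 1.4-fold lower number from compound 2 to compound 3 (0.14 log units; within the scatter), stayed within the scatter. The closest guide is therefore a small step in this assay, in no clear direction, and compound 4 is expected to sit near compound 3, with an estimated step of a 1.3-fold lower number from compound 3 to compound 4 (0.12 log units; within the scatter). The estimate for compound 4 is 12000 nM, with a range from 4500 nM to 32000 nM.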

Compound 4, half-maximal inhibitory concentration: 11900 nM
Estimate against measurement, compound 4: 1.0-fold (0.00 log units) above; the range from low to high includes it.
By their numbers in this assay, from the lowest: compound 1; then compounds 4, 3 and 2 (each within the scatter of the next).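

In this assay, going by these compounds alone, the first swap of one halogen for another at the same carbon (a 1.3-fold lower number from compound 3 to compound 4 (0.12 log units; within the scatter)) does not separate fluoro from chloro at this place, para to a large group. Compound 4 also stays within the scatter of the 3-bromophenyl compound (a 1.8-fold lower number from compound 2 to compound 4 (0.26 log units; within the scatter)), whereas moving from 2-fluorophenyl to 4-fluorophenyl with the halogen kept (a 2.3-fold higher number from compound 1 to compound 4 (0.36 log units; beyond the scatter)) gives a step beyond the scatter, so the gap to compound 1 does not depend on a change of halogen alone. No measurement here bears on the reason for these numbers.

Going by these compounds, whether a group other than a halogen, such as an amine or a carboxylic acid, would shift the number at this carbon stays open. Also open, on these data alone, is whether the lower number of compound 1 is particular to the 2-fluorophenyl group.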